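Bromo to iodo on the pyranone ring: a single-atom swap

The source may hold more compounds than are shown below. What is called first, only, known or untested is meant among the compounds shown, and "the series" means these compounds.

Measured so far:
Compound 1, `O=C1C=COC(/C=C/c2ccccc2)C1`: 122 uM
Compound 2, `COc1ccc(C2CC(=O)C=CO2)cc1`: 226 uM
Compound 3, `COc1ccc(C2CC(=O)C(Br)=CO2)cc1`: 46.4 uM

These three compounds were tested in a functional assay on U-251 cells (Homo sapiens) for inhibition, read by sulforhodamine B assay, with a stated time of 48 h; a lower number here means a stronger inhibitor of growth, a higher number a weaker inhibitor of growth. Compound 3 gives the lowest number of the three, so it is the strongest growth inhibitor in this set; compound 1 comes next, and compound 2 gives the highest number. Compound 2 and compound 3 share a core and differ only at one ring carbon, and the step of a 4.9-fold lower number from compound 2 to compound 3 (0.69 log units; beyond the scatter) shows that putting a halogen on that carbon made a clear difference.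

Compound 4, `COc1ccc(C2CC(=O)C(I)=CO2)cc1`, keeps the core of compound 3 and changes only that halogen: iodo in place of bromo on a double-bonded ring carbon. Going by the values given here, the only measured step that touches the same place is the one from compound 2 to compound 3, which replaced hydrogen with bromo. Among the compounds with values here, no measured pair shows what swapping one halogen for another does here, so the expectation leans on the fact that bromo already gave the low number of compound 3 and that iodo is a closely related group.

Compound 4 is therefore expected to stay near compound 3, with a change of a 1.3-fold lower number from compound 3 to compound 4 (0.12 log units; within the scatter), likely within the scatter or only slightly below it. The estimate for compound 4 is 35 uM, within a range from 14 uM to 90 uM.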

Compound 4, concentration for growth inhibition (reported as GI): 24.4 uM
Compound 4: middle estimate off by 1.4-fold (0.16 log units), on the high side, within the range that was stated.
By their numbers in this assay, from the lowest: compounds 4 and 3 (each within the scatter of the next); then compounds 1 and 2 (each within the scatter of the next).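

In this assay, swapping one halogen for the other gives a 1.9-fold lower number from compound 3 to compound 4 (0.28 log units; within the scatter), so bromo and iodo cannot be told apart on this double-bonded ring carbon. Measured against the parent with hydrogen at the same carbon, iodo gives a 9.3-fold lower number from compound 2 to compound 4 (0.97 log units; beyond the scatter), which shows that the lower number seen with bromo is not unique to that one halogen: two different halogens now give a lower number than hydrogen, on the same core. Nothing measured here speaks to the reason behind this result.

Hydrogen, bromo and iodo are the only groups shown on this carbon, so it remains open whether chloro, or a non-halogen group such as methyl or nitrile, would also give a lower number than hydrogen. It also remains open whether a halogen on this carbon would lower the number on the core of compound 1, which carries a different group on its ring and has no halogen partner among the compounds shown.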